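The source may report more compounds than this note shows. Statements on the series, on what has been measured and on what is new or still open speak of the compounds shown alone.

In an assay for inhibition of Neuropeptide Y receptor type 5 (Mus musculus) (on this read-out higher numbers stand for weaker inhibition and lower numbers for stronger inhibition), the three measured compounds are:

Compound 1 `COc1ccc(C(=O)c2cnc(Nc3cccc(C#N)c3)s2)cc1`: 2230 nM
Compound 2 `CCc1ccccc1C(=O)c1cnc(Nc2cccc(C(F)(F)F)c2)s1`: 32 nM
Compound 3 `Cc1ccccc1C(=O)c1cnc(Nc2cccc(C#N)c2)s1`: 4.2 nM

Compound 3 gives the lowest number of the three, that is the strongest inhibition. Compound 2 comes nearest, and compound 1 lies furthest away, as the step of a 530-fold lower number from compound 1 to compound 3 (2.73 log units; beyond the scatter) shows. Compound 4 `CCc1ccccc1C(=O)c1cnc(Nc2cccc(C#N)c2)s1` differs from compound 3 by methyl in place of hydrogen on a saturated chain carbon bound to an aromatic carbon. Among the measured compounds shown here, the only measured step, a 530-fold lower number from compound 1 to compound 3 (2.73 log units; beyond the scatter), changes a different part of the molecule and says nothing about this exchange. Compound 2 does carry the ethyl, and in this assay compound 2 gives 32 nM, yet it also carries trifluoromethyl where compound 3 carries nitrile, so the two values cannot separate what the ethyl alone does. A small step, perhaps toward a slightly higher number, is therefore expected: a 2.1-fold higher number from compound 3 to compound 4 (0.33 log units; beyond the scatter). Compound 4 is estimated at 9 nM, within 3 nM to 35 nM.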

Compound 4, half-maximal inhibitory concentration: 2.8 nM
The estimate for compound 4 lay 3.2-fold (0.51 log units) above the measured number; measured number outside the range, below it.
By their numbers in this assay, from the lowest: compounds 4 and 3 (each within the scatter of the next); then compound 2; then compound 1.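

Swapping 2-methylphenyl for 2-ethylphenyl gives a 1.5-fold lower number from compound 3 to compound 4 (0.18 log units; within the scatter) in this assay, so the extra methyl makes no measurable difference at this place. The nitrile and trifluoromethyl groups can now be compared on their own, which gives an 11-fold lower number from compound 2 to compound 4 (1.06 log units; beyond the scatter) and shows that this exchange matters far more, while 2-ethylphenyl in place of 4-methoxyphenyl gives an 800-fold lower number from compound 1 to compound 4 (2.90 log units; beyond the scatter) as a second large step. No measurement shown explains these differences. From the compounds shown here alone, whether a longer chain such as propyl or butyl would fit equally well at this place remains open. So does the effect of an amine or a carboxylic acid on that chain.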